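Taking the methoxy off compound 3

The source may hold more compounds than are shown below. What is called first, only, known or untested is meant among the compounds shown, and "the series" means these compounds.

Measured in a functional assay on A549/CDDP cells (Homo sapiens) for antiproliferative activity, read by MTT assay, with a stated time of 72 h; a higher number here means a weaker inhibitor, a lower number a stronger inhibitor:
- compound 1 `Cc1nc(C)c(/C=C/C(=O)/C=C/c2ccc(O)cc2)nc1C`: 4790 nM
- compound 2 `COc1ccccc1/C=C/C(=O)/C=C/c1nc(C)c(C)nc1C`: 4740 nM
- compound 3 `COc1ccc(/C=C/C(=O)/C=C/c2nc(C)c(C)nc2C)cc1`: 3610 nM

Compound 3, at 3610 nM, lies within the usual scatter of both other compounds, so the three cannot be ranked. The next structure is compound 4 `Cc1nc(C)c(/C=C/C(=O)/C=C/c2ccccc2)nc1C`, with hydrogen in place of methoxy on an aromatic carbon. Going by the values given here, the one measured step that bears on this is a 1.3-fold lower number from compound 1 to compound 3 (0.12 log units; within the scatter), for methyl in place of hydrogen on an oxygen on an aromatic ring. It stayed within the scatter, but there the oxygen remained, so it is only a loose guide. No step beyond the scatter is therefore expected in this assay, and no direction can be named. The expected change is a 1.2-fold higher number from compound 3 to compound 4 (0.08 log units; within the scatter). The estimate for compound 4 is 4300 nM, with an expected range of 2100 nM to 8800 nM.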

Compound 4, half-maximal inhibitory concentration: 11900 nM
Compound 4: middle estimate off by 2.8-fold (0.44 log units), on the low side; measured number outside the range, above it.
By their numbers in this assay, from the lowest: compounds 3, 2 and 1 (each within the scatter of the next); then compound 4.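

In this assay, the compound with no group on this ring carbon stands apart: losing the methoxy gives a clear rise (a 3.3-fold higher number from compound 3 to compound 4 (0.52 log units; beyond the scatter)), and the same holds for the other methoxy compound (a 2.5-fold higher number from compound 2 to compound 4 (0.40 log units; beyond the scatter)) and for the hydroxy compound (a 2.5-fold higher number from compound 1 to compound 4 (0.40 log units; beyond the scatter)). Compounds 1, 2 and 3 lie within the scatter of one another, so among these compounds having an oxygen-linked group on the ring matters more than which one it is. Nothing available explains this rise. From the compounds shown here alone, whether a group without oxygen, such as a fluorine atom or an amine, would keep the number as low remains open.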